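This account rests on a few compounds, and the source may have more. Where it says the series, first, only, none or still open, it means among the compounds named here.

Working notes on the series. Compound 2 `O=c1[nH]cnc2c1c(-c1ccsc1)cn2[C@@H]1O[C@H](CO)[C@@H](O)[C@H]1O` sits at the bottom of what the numbers show: in a functional assay on CEM-DNR-bulk cells (Homo sapiens), read by MTT assay, with a stated time of 72 h (a higher number here means a weaker inhibitor, a lower number a stronger inhibitor), compound 2 gives > 20000 nM, which is a limit of the assay and not a number. Compound 1 `O=c1[nH]cnc2c1c(-c1ccoc1)cn2[C@@H]1O[C@H](CO)[C@@H](O)[C@H]1O` in this assay gives > 20000 nM, also a limit. The step that the two limits leave unreadable from compound 1 to compound 2 is accordingly unreadable, as both entries rest on (the limit of > 20000 nM in this assay, at which 2 of the 2 values shown sit).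

Compound 3 `O=c1[nH]cnc2c1c(-c1cc3ccccc3o1)cn2[C@@H]1O[C@H](CO)[C@@H](O)[C@H]1O` differs from compound 2 by 1-benzofuran-2-yl in place of thiophen-3-yl on an aromatic carbon. Going by the values given here, no measured step of readable size bears on this change, so no step beyond the scatter is expected in this assay in either direction. Compound 3 is therefore estimated at 20000 nM, within 5000 nM to 60000 nM. The expected step of a number no higher from compound 2 to compound 3 (the limit leaves the size open) is itself an estimate only.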

Compound 3, half-maximal inhibitory concentration: > 20000 nM
Compound 3: no number, only a limit; the forecaster's own chance of this, stated with the estimate: 70%; the middle value lies on the limit itself.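

Compound 3 gives only a limit of the assay, as do compound 1 and compound 2, so no step among these compounds can be read in this assay: the limit of > 20000 nM in this assay, at which 3 of the 3 values shown sit.

The compounds shown leave open which group at this place on the shared core, if any, would give a readable number.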